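Amide tail variation at the chain end of the series

The source may hold more compounds than are shown below. What is called first, only, known or untested is meant among the compounds shown, and "the series" means these compounds.

Compound 1 `COc1ccc(-c2oc3c(OC)c(OC)cc(OCCCC(=O)NCc4ccccn4)c3c(=O)c2O)cc1` gives > 40000 nM in a functional assay on A549 cells (Homo sapiens) for antiproliferative activity, read by sulforhodamine B assay, with a stated time of 48 h (a lower number here means a stronger inhibitor, a higher number a weaker inhibitor), which is a limit of the assay and not a number.
Compound 2 `CCCCN(C)C(=O)CCCCOc1cc(OC)c(OC)c2oc(-c3ccc(OC)cc3)c(O)c(=O)c12` gives 16700 nM in this assay.

Compound 2 holds the only number shown in this assay; the other value is a limit. Going by the values given here, the sole measured step is an at least 2.3-fold lower number from compound 1 to compound 2 (0.37 log units; beyond the scatter), a change at the amide end of the chain that moved the value off the limit of > 40000 nM in this assay, at which 1 of the 2 values shown sits, and onto a number.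

Compound 3 `COc1ccc(-c2oc3c(OC)c(OC)cc(OCCCCC(=O)N4CCN(C)CC4)c3c(=O)c2O)cc1` carries the change (4-methylpiperazin-1-yl in place of butyl(methyl)amino on a carbonyl carbon). This touches the same amide terminus that the measured step altered, so that step is the only one bearing on it, and it was at least modest. It runs in the opposite sense, however, from an open-chain amine to a ring, and the data give no sign of direction for such a swap. No step beyond the scatter is therefore expected; the estimated step is a 1.1-fold lower number from compound 2 to compound 3 (0.05 log units; within the scatter), and compound 3 is expected to give about 15000 nM in this assay, within 5000 nM to 40000 nM.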

Compound 3, half-maximal inhibitory concentration: > 40000 nM
Compound 3 ended at the assay's limit (the forecaster's own chance of this, stated with the estimate: 20%); middle value at least 2.6-fold (0.42 log units) from the limit.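

At the amide terminus, on a carbonyl carbon whose other neighbour is a saturated chain carbon, 4-methylpiperazin-1-yl in place of butyl(methyl)amino gives an at least 2.3-fold higher number from compound 2 to compound 3 (0.37 log units; beyond the scatter) in this assay, so this position does respond to the amine on the carbonyl and the swap from open chain to ring costs activity. The step between compound 1 and compound 3 cannot be read, as both values are limits. The limit is now shared by the two tails that carry a ring, leaving the open-chain butyl(methyl)amino tail of compound 2 as the only one in this set that comes off it: the limit of > 40000 nM in this assay, at which 2 of the 3 values shown sit.

Going by these compounds, it remains open whether the loss in compound 3 follows from closing the amine into a ring or from the second ring nitrogen, a distinction that a piperidine amide or a morpholine amide on the same carbonyl carbon could draw. Also open, on these data alone, is how far the open-chain side can go beyond compound 2 at 16700 nM, for instance with a dibutylamino group or a longer chain.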